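The source may hold more compounds than are shown below. What is called first, only, known or untested is meant among the compounds shown, and "the series" means these compounds.

Compound 2 `CNc1nc2c(C)c(Cc3cccnc3)c(O)c(C)c2s1` and compound 1 `CNc1nc2c(Cc3cccnc3)c(C)c(O)c(C)c2s1` share one core and differ only in where the pyridylmethyl and methyl groups sit. In a functional assay for inhibition of Thromboxane-A synthase (Rattus norvegicus) (a higher number here means a weaker inhibitor, a lower number a stronger inhibitor), compound 1 gives 90 nM. In this assay compound 2 is reported only as a limit, < 100 nM, not as an exact number; (the limit of < 100 nM in this assay, at which 1 of the 2 values shown sits). Compound 3 `CCNc1nc2c(C)c(Cc3cccnc3)c(O)c(C)c2s1` differs from compound 2 by a single change: methyl in place of hydrogen on a saturated chain carbon bound to a nitrogen on an aromatic ring. Within the data shown here, no measured pair shows this change, so the step is expected to be small, none beyond the scatter, namely a step that the limit leaves unreadable from compound 2 to compound 3. Compound 3 is therefore expected to give about 60 nM, within a range from 20 nM to 200 nM.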

Compound 3, half-maximal inhibitory concentration: 650 nM
Beside the measured number, compound 3's estimate is 11-fold (1.03 log units) below it, outside the stated range (above it).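

In this assay, replacing methylamino with ethylamino gives an at least 6.5-fold higher number from compound 2 to compound 3 (0.81 log units; beyond the scatter). The earlier compounds shown here could not show that this position is sensitive, but here a single added methyl on this saturated chain carbon weakens inhibition beyond the usual scatter. The exact size of the step stays unknown, as compound 2 is reported only as a limit: the limit of < 100 nM in this assay, at which 1 of the 3 values shown sits.

As far as these compounds go, it remains open whether a longer chain, such as propylamino, would weaken inhibition further. From the compounds shown here alone, how a plain amino group at this position would compare also remains open.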